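Toward a Trifluorobenzyl Analogue of an Indole Diketo Ester

The compounds below may be only part of what the source reports. "The series", "measured", "known", "first", "only" and "open" are said of these compounds alone.

The measured set is small: compound 1 `COc1cccc2c1c(C(=O)/C=C(\O)C(=O)O)cn2Cc1ccc(F)c(F)c1`, compound 2 `CCOC(=O)/C(O)=C/C(=O)c1cn(Cc2cc(F)cc(F)c2)c2cccc(OC)c12` and compound 3 `COc1cccc2c1c(C(=O)/C=C(\O)C(=O)O)cn2Cc1ccc(F)cc1F`. In an ADME assay on MT4 cells (Homo sapiens) for cytotoxicity, read by MTT assay (on this read-out higher numbers stand for lower toxicity in this test and lower numbers for higher toxicity in this test), compound 1 gives 71000 nM. In this assay compound 2 gives 34700 nM. In this assay compound 3 gives 20800 nM.

Compound 2 stands second of the three numbers: compound 1 is separated from it beyond the scatter, with the larger number, whereas the gap between compound 2 and compound 3 stays within the scatter, so no order between those two can be read.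

Compound 4 `CCOC(=O)/C(O)=C/C(=O)c1cn(Cc2ccc(F)c(F)c2F)c2cccc(OC)c12` is not yet measured. It differs from compound 2 by 2,3,4-trifluorophenyl in place of 3,5-difluorophenyl on a saturated chain carbon bound to an aromatic nitrogen. Going by the values given here, only one measured step bears on a change at that place, the rearrangement of fluorines in a 3.4-fold lower number from compound 1 to compound 3 (0.53 log units; beyond the scatter), a modest shift on the acid core rather than the ester of compound 2. A change at the same place in compound 4 is therefore expected to give a step of about a 1.4-fold lower number from compound 2 to compound 4 (0.14 log units; within the scatter) in this assay, modest and possibly within the scatter. Compound 4 is estimated at 25000 nM, within 10000 nM to 60000 nM.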

Compound 4, half-maximal cytotoxic concentration: 42700 nM
Compound 4: the middle estimate sits 1.7-fold (0.23 log units) below what was measured, and the stated range covers the measured number.
By their numbers in this assay, from the lowest: compounds 3, 2, 4 and 1 (each within the scatter of the next, the first and the last beyond it).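

On the core of compound 2, the change to 2,3,4-trifluorophenyl on a saturated chain carbon bound to an aromatic nitrogen gives a 1.2-fold higher number from compound 2 to compound 4 (0.09 log units; within the scatter) in this assay, so this swap, which also adds a fluorine, leaves no readable change in the number. Going by these compounds alone, the only earlier step at this place, a 3.4-fold lower number from compound 1 to compound 3 (0.53 log units; beyond the scatter), was a rearrangement of fluorines on the core of compound 1 and lay beyond the scatter, whereas this first step on the ethyl ester does not. Nothing available explains why the step is this small.

Going by these compounds, it remains open whether the same exchange would give a readable step on the core of compound 1, with its free carboxylic acid in place of the ethyl ester. Also open, on these data alone, is whether an unsubstituted phenyl or a chlorophenyl at this place would move the number beyond the scatter.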